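A smaller aryl group on the ring nitrogen

A few compounds are considered here, and "the series" means these few. Any claim that something is new, unique, unknown or untested is made for them only; others in the source may bear on it.

Of the compounds shown here, three that share one core have been tested in a functional assay on HL-60 cells (Homo sapiens) for inhibition, read by MTT assay, with a stated time of 72 h; on this read-out higher numbers stand for weaker inhibition and lower numbers for stronger inhibition. Compound 1 `Cc1nc(-c2ccccc2)c(C(=O)N2CCN(c3cccc(C(N)=O)c3)CC2)o1` gives 71 nM. Among the compounds with values here, compound 3 `CCOc1cccc(N2CCN(C(=O)c3oc(C)nc3-c3ccccc3)CC2)c1` gives 151 nM, the higher of the two numbers known, and the step of a 2.1-fold higher number from compound 1 to compound 3 (0.33 log units; beyond the scatter) is modest. Compound 2 `Cc1ccc(N2CCN(C(=O)c3oc(C)nc3-c3ccccc3)CC2)cc1` reaches only the limit of this assay, > 1000 nM, so no number exists for it (the limit of > 1000 nM in this assay, at which 1 of the 3 values shown sits). The remaining steps are an at least 14-fold higher number from compound 1 to compound 2 (1.14 log units; beyond the scatter) and an at least 6.6-fold lower number from compound 2 to compound 3 (0.82 log units; beyond the scatter).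

Compound 4 `Cc1nc(-c2ccccc2)c(C(=O)N2CCN(c3ccccc3F)CC2)o1` has not been measured. Relative to compound 3 the change is 2-fluorophenyl in place of 3-ethoxyphenyl on an amine nitrogen in a ring. Within the data shown here, the steps that bear on this are the two that swap the aryl group on the ring nitrogen: the step from compound 1 to compound 2 was large, and the step from compound 2 to compound 3 was at least modest, whereas the step from compound 1 to compound 3 was only modest. Compound 4 carries neither a carbamoyl nor an ethoxy group and, like compound 2, brings no hydrogen-bond acceptor on that ring, so a higher number than for compound 3 is expected, though with wide uncertainty. The estimate for compound 4 in this assay is 400 nM, with a range from 100 nM to 2000 nM. This expected step is a 2.6-fold higher number from compound 3 to compound 4 (0.42 log units; beyond the scatter).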

Compound 4, half-maximal inhibitory concentration: 147 nM
Compound 4: middle estimate off by 2.7-fold (0.43 log units), on the high side, and the stated range covers the measured number.
By their numbers in this assay, from the lowest: compound 1; then compounds 4 and 3 (each within the scatter of the next). At a limit, above all of these: compound 2.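

In this assay the swap gives a 1.0-fold lower number from compound 3 to compound 4 (0.01 log units; within the scatter), so on this ring nitrogen 2-fluorophenyl, which counts 0 hydrogen-bond acceptors, serves as well as 3-ethoxyphenyl, which counts 1, and an acceptor on the aryl group is not needed to reach this level among these two compounds. The other two new steps are an at least 6.8-fold lower number from compound 2 to compound 4 (0.83 log units; beyond the scatter) and a 2.1-fold higher number from compound 1 to compound 4 (0.32 log units; beyond the scatter), which means that having neither a carbamoyl nor an ethoxy group does not by itself bring the loss seen for compound 2, while 3-carbamoylphenyl still gives the lowest number. Compound 2 stands at a limit and not at a number, so the step that involves it gives only a minimum size: the limit of > 1000 nM in this assay, at which 1 of the 4 values shown sits.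

The compounds shown do not tell whether the gap between 2-fluorophenyl and 4-methylphenyl comes from the group itself or from where it sits on the aryl ring, a question that a 4-fluorophenyl or a 2-methylphenyl group on the same nitrogen would address. They also leave open whether an amine or a carboxylic acid in place of the carbamoyl group would match compound 1 at 71 nM.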